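The source may hold more compounds than are shown below. What is called first, only, known or untested is meant among the compounds shown, and "the series" means these compounds.

Measured compounds in an assay on isolated protein for agonist activity at Bile acid receptor (Homo sapiens), read by TR-FRET; a higher number here means that more compound is needed for the effect, a lower number that less compound is needed:

Compound 1, `CCC(CC)n1c(-c2ccc(OCc3c(-c4c(Cl)cccc4Cl)noc3C(C)C)cc2F)nc2ccc(C(=O)O)cc21`, gives 69.3 nM.
Compound 2, `CC(C)c1onc(-c2c(Cl)cccc2Cl)c1COc1ccc(-c2nc3ccc(C(=O)O)cc3n2CC(C)(C)C)cc1`, gives 24.8 nM.
Compound 3, `CC(C)c1onc(-c2c(Cl)cccc2Cl)c1COc1ccc(-c2nc3ccc(C(=O)O)cc3n2C2CC2)cc1`, gives 117 nM.

Compound 3 has the highest number of the three in this assay, so it needs the most compound for the effect. Its value and that of compound 1 sit within the usual scatter of each other, so no order between those two can be claimed. Against compound 2 the gap is real: a 4.7-fold higher number from compound 2 to compound 3 (0.67 log units; beyond the scatter).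

Compound 4, `CC(C)c1onc(-c2c(Cl)cccc2Cl)c1COc1ccc(-c2nc3ccc(C(=O)O)cc3n2CC2CCCCC2)cc1`, has not been measured. It differs from compound 3 in one place: cyclohexylmethyl in place of cyclopropyl on an aromatic nitrogen. For the measured compounds named here, the only measured step that bears on this change is the one from compound 2 to compound 3, where swapping neopentyl for cyclopropyl on the same aromatic nitrogen raised the number beyond the scatter. Cyclohexylmethyl, like neopentyl, is a larger group than cyclopropyl, so the expectation for compound 4 is a step back toward the lower numbers seen for compound 2 and compound 1, of roughly a 3.3-fold lower number from compound 3 to compound 4 (0.52 log units; beyond the scatter). The estimate for compound 4 is therefore 35 nM, with a likely range from 12 nM to 100 nM, because compound 2 reached 24.8 nM with a group of comparable size in the same place.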

Compound 4, half-maximal effective concentration: 19.9 nM
Compound 4: the middle estimate sits 1.8-fold (0.25 log units) above what was measured; measured number inside the range.
By their numbers in this assay, from the lowest: compounds 4 and 2 (each within the scatter of the next); then compounds 1 and 3 (each within the scatter of the next).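

Replacing cyclopropyl with cyclohexylmethyl on this aromatic nitrogen in this assay gives a 5.9-fold lower number from compound 3 to compound 4 (0.77 log units; beyond the scatter) and shows that the drop in the number seen with neopentyl is not unique to that group. Changing tert-butyl to cyclohexyl on the saturated chain carbon bound to that nitrogen gives a 1.2-fold lower number from compound 2 to compound 4 (0.10 log units; within the scatter) and so leaves neopentyl and cyclohexylmethyl with no order between them. Among the compounds that differ only at this position, the low number is therefore shared by two groups with different ends, while cyclopropyl in compound 3 stands apart from both.

Going by these compounds, it remains open whether a longer straight chain, or an amine or a hydroxyl group on the cyclohexyl ring, would keep the number this low. Nothing measured here explains why these groups differ from cyclopropyl.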